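The source may hold more compounds than are shown below. What is called first, only, known or untested is meant among the compounds shown, and "the series" means these compounds.

Compound 1 `O=S(=O)(c1ccc(Nc2nccc(Nc3ccc4nc[nH]c4c3)n2)cc1)N1CCOCC1`: > 25000 nM (a limit)
Compound 2 `O=C(Nc1ccccc1)Nc1ccc(Nc2nccc(Nc3ccc4cn[nH]c4c3)n2)cc1`: 11000 nM

Going by the values given here, in a functional assay on HepG2 cells (Homo sapiens) for inhibition, read by fluorescence and resazurin assay, with a stated time of 72 h (a lower number here means a stronger inhibitor, a higher number a weaker inhibitor), compound 2 stands at 11000 nM as the only actual number so far. Compound 1 gives > 25000 nM as a limit and not a number. Compound 3 `O=C1NC(Cc2ccc(Nc3nccc(Nc4ccc5cn[nH]c5c4)n3)cc2)CO1` carries (2-oxo-1,3-oxazolidin-4-yl)methyl in place of (phenylcarbamoyl)amino on an aromatic carbon, para to a large group ((2-oxo-1,3-oxazolidin-4-yl)methyl in place of (phenylcarbamoyl)amino on an aromatic carbon). Among the compounds with values here, no measured step covers this change. A modest weakening in this assay is expected, with a 2.3-fold higher number from compound 2 to compound 3 (0.36 log units; beyond the scatter) as the estimated step. For compound 3 the estimated value is 25000 nM (expected range 9000 nM to 70000 nM).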

Compound 3, half-maximal inhibitory concentration: 20000 nM
Compound 3: middle estimate off by 1.3-fold (0.10 log units), on the high side, and the stated range covers the measured number.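

In this assay, (2-oxo-1,3-oxazolidin-4-yl)methyl in place of (phenylcarbamoyl)amino on this aromatic carbon gives a 1.8-fold higher number from compound 2 to compound 3 (0.26 log units; within the scatter). This first readable step at the position shows that two quite different groups, one with a six-membered aromatic ring of carbon only and one without, cannot be told apart here. Compound 1 remains a limit and not a number: the limit of > 25000 nM in this assay, at which 1 of the 3 values shown sits.

Neither group shows a way to a much lower number. On these data alone, whether an amine, a carboxylic acid or a longer chain on this carbon would give one stays open.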